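Replacing a diethylamino chain end with hydroxy

This account rests on a few compounds, and the source may have more. Where it says the series, first, only, none or still open, it means among the compounds named here.

Compound 1 `COC(=O)CNc1ncnc2c1C(=O)C(OC)=CC2=O`: 4260 nM
Compound 2 `CCN(CC)CCCNc1ncnc2c1C(=O)C(OC)=CC2=O`: 1240 nM

In a functional assay on L1210 cells (Mus musculus) for inhibition (a lower number here means a stronger inhibitor, a higher number a weaker inhibitor), compound 2 has the lower of the two numbers. Compound 3 `COC1=CC(=O)c2ncnc(NCCO)c2C1=O` carries hydroxy in place of (diethylamino)methyl (hydroxy in place of (diethylamino)methyl on a saturated chain carbon, two bonds along the chain from a nitrogen on an aromatic ring) on a saturated chain carbon, two bonds along the chain from a nitrogen on an aromatic ring. Among the measured compounds shown here, one measured step bears on this change, a modest one that also introduced the diethylamino group (a 3.4-fold lower number from compound 1 to compound 2 (0.54 log units; beyond the scatter)). Removing that group is therefore expected to give a step of similar size towards a higher number. For compound 3 the estimate is 2800 nM (expected range 900 nM to 8000 nM). The estimated change is modest (a 2.3-fold higher number from compound 2 to compound 3 (0.35 log units; beyond the scatter)).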

Compound 3, half-maximal inhibitory concentration: 7130 nM
Beside the measured number, compound 3's estimate is 2.5-fold (0.41 log units) below it; measured number inside the range.
By their numbers in this assay, from the lowest: compound 2; then compounds 1 and 3 (each within the scatter of the next).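

In this assay, exchanging (diethylamino)methyl for hydroxy at this place on the chain gives a clear step (a 5.8-fold higher number from compound 2 to compound 3 (0.76 log units; beyond the scatter)). The hydroxymethyl and methoxycarbonyl ends, by contrast, are not separated (a 1.7-fold higher number from compound 1 to compound 3 (0.22 log units; within the scatter)), so among these three compounds only compound 2, with its diethylamino end, stands apart. As far as these compounds go, whether that comes from the terminal amine or from the chain length stays open; a primary amine on the same chain, or a longer chain ending in hydroxy, would bear on this. The data given offer no explanation for the difference.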